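The source may hold more compounds than are shown below. What is called first, only, known or untested is meant among the compounds shown, and "the series" means these compounds.

In an assay on CHO cells for displacement of a labelled ligand from prostaglandin E2 receptor EP1 subtype (Homo sapiens) (a lower number here means a stronger inhibitor, a higher number a weaker inhibitor), three compounds have numbers. Compound 1 `CCc1ccccc1N(CC(=O)NCc1cccc(OC)c1)S(=O)(=O)c1ccc(C)cc1` gives 79.4 nM. Compound 2 `Cc1ccc(S(=O)(=O)N(CC(=O)NCc2ccc(Cl)cc2)c2cccnc2C)cc1` gives 200 nM, the second highest of the three: its nearest neighbour is compound 3 `Cc1ccc(S(=O)(=O)N(CC(=O)NCc2ccc(Cl)cc2)c2ccnn2C)cc1`, which gives 398 nM, and the furthest is compound 1, whose number is lower by a gap beyond the scatter. Compound 4 `CCn1nccc1N(CC(=O)NCc1ccc(Cl)cc1)S(=O)(=O)c1ccc(C)cc1` has not been measured; it differs from compound 2 by 1-ethyl-1H-pyrazol-5-yl in place of 2-methylpyridin-3-yl on a sulfonamide nitrogen. Among the measured compounds shown here, the one measured step that bears on this change is the one from compound 2 to compound 3, which also replaces the pyridinyl group with a pyrazolyl group and gives a 2.0-fold higher number from compound 2 to compound 3 (0.30 log units; within the scatter). For the measured compounds named here, compound 4 carries an ethyl rather than a methyl on that pyrazole, and no measured pair shows what that alteration does. Compound 4 is therefore expected to sit close to compound 3, with a step of about a 1.8-fold higher number from compound 2 to compound 4 (0.24 log units; within the scatter) in this assay, which lies within the scatter. The estimated value of compound 4 is 350 nM, with a range from 150 nM to 900 nM.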

Compound 4, inhibition constant: 158 nM
Estimate against measurement, compound 4: 2.2-fold (0.35 log units) above; low and high end bracket the measured number.
By their numbers in this assay, from the lowest: compounds 1, 4, 2 and 3 (each within the scatter of the next, the first and the last beyond it).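

In this assay, among the compounds shown here, the pyrazole's substituent proves to matter: lengthening its methyl to ethyl gives a 2.5-fold lower number from compound 3 to compound 4 (0.40 log units; beyond the scatter), a modest step and the first measured change on this group that lies beyond the scatter. Against the pyridine, the swap to 1-ethyl-1H-pyrazol-5-yl on the sulfonamide nitrogen gives a 1.3-fold lower number from compound 2 to compound 4 (0.10 log units; within the scatter), so at this position the five-membered ring with the ethyl group and the six-membered ring of compound 2 cannot be told apart. No measurement shown gives a reason for the effect of the added methyl on the chain carbon.

From the compounds shown here alone, whether a propyl or a cyclopropyl group on that pyrazole nitrogen would carry the trend further remains open. So does what a pyrazole with only hydrogen there would give.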